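Extending the hydroxyethyl chain of compound 3 with a 3-hydroxyphenyl ether

The source may hold more compounds than are shown below. What is called first, only, known or untested is meant among the compounds shown, and "the series" means these compounds.

Measured compounds:
compound 1, `COC(=O)c1c(F)cccc1-c1ccc(CCc2ncc(CC(C)(C)C)n2CCC(=O)O)cc1`, 3 nM
compound 2, `COC(=O)c1c(F)cccc1-c1ccc(CCc2ncc(CC(C)(C)C)n2Cc2ccc(C(=O)O)cc2)cc1`, 5 nM
compound 3, `COC(=O)c1c(F)cccc1-c1ccc(CCc2ncc(CC(C)(C)C)n2CCO)cc1`, 24 nM

In an assay on cells for agonist activity at Bombesin receptor subtype-3 (Mus musculus), read by HTRF and inositol phosphate accumulation, with a stated time of 1 h (a lower number here means that less compound is needed, a higher number that more compound is needed for the effect), compound 3 gives 24 nM, the highest of the three numbers: the nearest step is a 4.8-fold higher number from compound 2 to compound 3 (0.68 log units; beyond the scatter) and the furthest is an 8.0-fold higher number from compound 1 to compound 3 (0.90 log units; beyond the scatter). Compound 4 `COC(=O)c1c(F)cccc1-c1ccc(CCc2ncc(CC(C)(C)C)n2CCOc2cccc(O)c2)cc1` differs from compound 3 by 3-hydroxyphenyl in place of hydrogen on an oxygen on a saturated carbon. For the measured compounds named here, no measured step covers this change directly. The closest guide is a 1.7-fold higher number from compound 1 to compound 2 (0.22 log units; within the scatter), where an aryl ring on the chain carbon bound to the aromatic nitrogen left the number within the scatter, while an 8.0-fold higher number from compound 1 to compound 3 (0.90 log units; beyond the scatter) shows the hydroxy chain end costing a modest step. The account therefore expects for compound 4 a 2.0-fold lower number from compound 3 to compound 4 (0.30 log units; within the scatter), at most a modest downward step. The estimate for compound 4 is 12 nM, within 3 nM to 50 nM.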

Compound 4, half-maximal effective concentration: 25 nM
Estimate against measurement, compound 4: 2.1-fold (0.32 log units) below; low and high end bracket the measured number.
By their numbers in this assay, from the lowest: compounds 1 and 2 (each within the scatter of the next); then compounds 3 and 4 (each within the scatter of the next).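

In this assay, adding 3-hydroxyphenyl on the oxygen of the hydroxyethyl chain leaves the reading level, with a 1.0-fold higher number from compound 3 to compound 4 (0.02 log units; within the scatter) within the scatter, so this position accepts the added ring without any change that can be read. The ether does not close the distance to the carboxylic acids either: there is a 5.0-fold higher number from compound 2 to compound 4 (0.70 log units; beyond the scatter) and also an 8.3-fold higher number from compound 1 to compound 4 (0.92 log units; beyond the scatter) as modest steps. No evidence is available that bears on the reason for this. On these data alone, whether a carboxylic acid on the ring of the 3-hydroxyphenoxy group, or an amine at the chain end, would bring the number nearer to those of compound 1 and compound 2 stays open, as does the effect of a longer chain carrying the same ring.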